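A few compounds are considered here, and "the series" means these few. Any claim that something is new, unique, unknown or untested is made for them only; others in the source may bear on it.

Measured so far:

Compound 1 `COc1cccc(/C=C/C(=O)c2sc(Nc3ccc(Cl)cc3)nc2C)c1` gives > 25000 nM in a functional assay on PC-3 cells (Homo sapiens) for cytotoxicity, read by MTT assay (on this read-out lower numbers stand for stronger inhibition and higher numbers for weaker inhibition), which is a limit of the assay and not a number.
Compound 2 `COc1cccc(/C=C/C(=O)c2sc(Nc3ccccc3)nc2C)c1` gives > 25000 nM in this assay, again a limit of the assay.
Compound 3 `Cc1nc(Nc2cccc(Cl)c2)sc1C(=O)/C=C/c1ccccc1` gives > 25000 nM in this assay, once more a limit of the assay.

Compound 1 and compound 2 differ in one place: chloro in place of hydrogen on an aromatic carbon. The step this makes in this assay is a step that the two limits leave unreadable from compound 2 to compound 1, so its size cannot be read. The reason is the limit of > 25000 nM in this assay, at which 3 of the 3 values shown sit, which leaves no room to see any effect of the change. How the core of compound 3 differs from that of compound 2 is not broken down here.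

Compound 4 `Cc1nc(Nc2ccc(Cl)c(Cl)c2)sc1C(=O)/C=C/c1ccccc1` has not yet been measured. It differs from compound 3 in one place: chloro in place of hydrogen on an aromatic carbon. Among the compounds with values here, this is the same kind of change as the one from compound 2 to compound 1, but not the same: in compound 4 the entering chloro group sits ortho to a chloro group, whereas in compound 1 no such neighbour is present.

Within the data shown here, since every compound so far sits at the limit, no step can be read, and there is no basis for expecting compound 4 to behave differently. The step from compound 3 to compound 4 in this assay is expected to be a step that the limit leaves unreadable from compound 3 to compound 4. Compound 4 is estimated at 30000 nM, between 8000 nM and 120000 nM, most likely reported as a limit again.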

Compound 4, half-maximal inhibitory concentration: 7990 nM
Beside the measured number, compound 4's estimate is 3.8-fold (0.57 log units) above it; measured number outside the range, below it.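

In this assay, putting chloro in place of hydrogen on an aromatic carbon of the 3-chlorophenyl group gives an at least 3.1-fold lower number from compound 3 to compound 4 (0.49 log units; beyond the scatter), so on this core the change can be seen to matter. The same kind of change on the other core, from compound 2 to compound 1, cannot be read, because both of those compounds sit at a limit of the assay and not at a number: the limit of > 25000 nM in this assay, at which 3 of the 4 values shown sit. This means that the change is not shown to carry from one core to the other, nor shown to fail, since the two cores differ and the entering chloro sits ortho to a chloro group in compound 4, whereas compound 1 has no such neighbour.

The compounds shown leave open whether the 3,4-dichlorophenyl group would lift the core of compound 2 off the limit in the same way, which would separate the effect of the core from that of the neighbouring chloro. They also leave open whether a bromo or a trifluoromethyl group entering in place of the new chloro would give a similar step.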